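Pyridine in place of phenyl on the anilino nitrogen

This account rests on a few compounds, and the source may have more. Where it says the series, first, only, none or still open, it means among the compounds named here.

Compound 1 `COc1ccc(Nc2nc(Oc3cccc(NC(=O)C=C(C)C)c3)c3sccc3n2)cc1` gives 46100 nM.
Compound 2 `COc1ccc(Nc2nc(Oc3cccc(NC(=O)/C=C/C(C)C)c3)c3sccc3n2)cc1` gives > 50000 nM.
Compound 3 `C=CC(=O)Nc1cccc(Oc2nc(Nc3cccc(OC)c3)nc3ccsc23)c1` gives 19000 nM.

All three were tested in a functional assay on MCF7 cells (Homo sapiens) for inhibition, read by MTT assay, with a stated time of 72 h; a higher number here means a weaker inhibitor, a lower number a stronger inhibitor. Compound 2 gives only a limit of the assay, > 50000 nM, and sits at the limit of > 50000 nM in this assay, at which 1 of the 3 values shown sits. Among the measured compounds shown here, the single measured step, an at least 1.0-fold higher number from compound 1 to compound 2 (0.03 log units; that floor lies within the scatter), concerns the group on the carbonyl carbon and does not involve the part changed here. Compound 4 `COc1ccc(Nc2nc(Oc3cccc(NC(=O)/C=C/C(C)C)c3)c3sccc3n2)cn1` differs from compound 2 by 6-methoxypyridin-3-yl in place of 4-methoxyphenyl on a nitrogen on an aromatic ring. For the measured compounds named here, no measured step bears on this change, so no shift beyond the scatter is expected; a number no higher from compound 2 to compound 4 (the limit leaves the size open) is the estimated step. Compound 4 is expected to give 50000 nM, within 25000 nM to 120000 nM, and will most likely again be reported only as a limit.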

Compound 4, half-maximal inhibitory concentration: > 50000 nM
Compound 4 was reported as a limit; the forecaster's own chance of this, stated with the estimate: 65%; the middle value lies on the limit itself.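

No step can be read from compound 2 to compound 4, since both stand only as limits in this assay: the limit of > 50000 nM in this assay, at which 2 of the 4 values shown sit.
The compounds shown leave open whether 6-methoxypyridin-3-yl in place of 4-methoxyphenyl shifts the number at all.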